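From 3,4-dichlorophenyl to 3,5-dichlorophenyl

The source may hold more compounds than are shown below. What is called first, only, known or untested is meant among the compounds shown, and "the series" means these compounds.

In a functional assay on A549 cells (Homo sapiens) for cytotoxicity, read by MTT assay, with a stated time of 72 h (a higher number here means a weaker inhibitor, a lower number a stronger inhibitor), compound 1 (`COc1ccc(/C=C2\CCC/C(=C\c3cccc(Cl)c3)C2=O)cc1OC`) gives 11000 nM, compound 2 (`COc1ccc(/C=C2\CCC/C(=C\c3ccc(Br)cc3)C2=O)cc1OC`) gives 16000 nM and compound 3 (`COc1ccc(/C=C2\CCC/C(=C\c3ccc(Cl)c(Cl)c3)C2=O)cc1OC`) gives 6900 nM. Compound 3 shares the bottom of this short range with compound 1, as shown by a 1.6-fold lower number from compound 1 to compound 3 (0.20 log units; within the scatter). Only a 2.3-fold lower number from compound 2 to compound 3 (0.37 log units; beyond the scatter) clears the scatter.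

Compound 4 (`COc1ccc(/C=C2\CCC/C(=C\c3cc(Cl)cc(Cl)c3)C2=O)cc1OC`) carries 3,5-dichlorophenyl in place of 3,4-dichlorophenyl on a double-bonded chain carbon bound to a double-bonded ring carbon. Going by the values given here, no measured step moves a chlorine in this way. The nearest evidence is the added chloro in a 1.6-fold lower number from compound 1 to compound 3 (0.20 log units; within the scatter), and the swap of aryl groups in a 1.5-fold higher number from compound 1 to compound 2 (0.16 log units; within the scatter) is also small. Across these few compounds, the aryl changes have moved this assay only slightly, so no step beyond the scatter is expected, with at most a small rise.

The estimate for compound 4 is a 1.2-fold higher number from compound 3 to compound 4 (0.09 log units; within the scatter). Compound 4 is expected at 8500 nM, with an estimated range of 4500 nM to 16000 nM.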

Compound 4, half-maximal inhibitory concentration: 5500 nM
Compound 4: middle estimate off by 1.5-fold (0.19 log units), on the high side; the range from low to high includes it.
By their numbers in this assay, from the lowest: compounds 4, 3, 1 and 2 (each within the scatter of the next, the first and the last beyond it).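

Placing the two chlorines as 3,5-dichlorophenyl instead of 3,4-dichlorophenyl gives the first direct reading of chlorine placement at this position in this assay, and with a 1.3-fold lower number from compound 3 to compound 4 (0.10 log units; within the scatter) it does not separate the two dichlorophenyl compounds. The 3,5-dichlorophenyl group also gives a 2.9-fold lower number from compound 2 to compound 4 (0.46 log units; beyond the scatter) and a 2.0-fold lower number from compound 1 to compound 4 (0.30 log units; within the scatter), so compound 4 joins compound 3 in standing clear of the 4-bromophenyl compound 2, while neither dichlorophenyl compound separates from the 3-chlorophenyl compound 1. No independent data bear on the reason for these small differences.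

Every aryl group shown here carries only chlorine or bromine, so the response to an amine, a carboxylic acid or a methoxy group at this position remains open. Also open, going by these compounds, is whether 3,5-dibromophenyl would track 3,5-dichlorophenyl in this assay.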